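Extending the ring-nitrogen substituent of a quinolinone series

A few compounds are considered here, and "the series" means these few. Any claim that something is new, unique, unknown or untested is made for them only; others in the source may bear on it.

Measured so far:
Compound 1, `COc1ccc(-c2cc3c(OC)ccc(OC)c3nc2O)cc1`: 10000 nM
Compound 2, `COc1ccc(-c2cc3c(OC)cc(OC)cc3n(C)c2=O)cc1`: 10000 nM

In a functional assay on A-427 cells (Homo sapiens) for cytotoxicity, read by colorimetric assay and MTT assay (on this read-out higher numbers stand for weaker inhibition and lower numbers for stronger inhibition), compound 1 gives 10000 nM and compound 2 gives 10000 nM, so compound 2 stands level with its nearest neighbour, within the scatter. Compound 3, `COc1ccc(-c2cc3c(OC)cc(OC)cc3n(CCCC#N)c2=O)cc1`, has not yet been tested in this assay; it carries 2-cyanoethyl in place of hydrogen on a saturated chain carbon bound to an aromatic nitrogen. Among the compounds with values here, no step between measured compounds informs this change, so the account expects a step of a 1.1-fold lower number from compound 2 to compound 3 (0.05 log units; within the scatter), meaning no change beyond the scatter. Compound 3 is therefore estimated at 9000 nM, with a range from 3000 nM to 25000 nM.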

Compound 3, half-maximal inhibitory concentration: 10000 nM
Compound 3: the middle estimate sits 1.1-fold (0.05 log units) below what was measured; the range from low to high includes it.
By their numbers in this assay, from the lowest: compounds 1, 2 and 3 (each within the scatter of the next).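

In this assay, within the data shown here, the step reads no change at the digits printed from compound 2 to compound 3 (within the scatter) and is the first to be read at this position, since the earlier compounds gave no step. It shows that extending methyl to 3-cyanopropyl on the ring nitrogen, which adds a nitrile at the end of the chain, leaves the number where it was. No measurement shown here offers an explanation for this result.

Going by these compounds, whether an amine or a carboxylic acid at the end of this chain, or a longer chain, would move the number remains open.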